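Adding a methoxy to the phenyl of compound 1

The source may hold more compounds than are shown below. What is called first, only, known or untested is meant among the compounds shown, and "the series" means these compounds.

Compound 1 `COc1ccc(Nc2nc(N)c(C(=O)c3ccccc3)s2)cc1` gives 230 nM
Compound 2 `Nc1nc(Nc2ccc(Cl)cc2)sc1C(=O)c1ccccc1` gives > 10000 nM as a limit
Compound 3 `Nc1nc(Nc2ccc(F)cc2)sc1C(=O)c1ccccc1` gives > 10000 nM as a limit

In a functional assay on MOLT-4 cells (Homo sapiens) for antiproliferative activity, read by cell counting, with a stated time of 2 days (on this read-out lower numbers stand for stronger inhibition and higher numbers for weaker inhibition), compound 1 alone has a readable number. Compounds 2 and 3 stand at the limit of > 10000 nM in this assay, at which 2 of the 3 values shown sit, instead. Chloro in place of methoxy gave an at least 43-fold higher number from compound 1 to compound 2 (1.63 log units; beyond the scatter), and fluoro in place of methoxy gave an at least 43-fold higher number from compound 1 to compound 3 (1.63 log units; beyond the scatter). Compound 4 `COc1ccc(Nc2nc(N)c(C(=O)c3ccccc3OC)s2)cc1` carries methoxy in place of hydrogen on an aromatic carbon, which is phenyl to 2-methoxyphenyl. Both large steps replace the existing methoxy, not a hydrogen on this phenyl, so neither sizes the new change. Within the data shown here, no measured step touches this phenyl, so the estimate starts from compound 1 at 230 nM and expects no change beyond the scatter, with a slight lean towards a higher number. The expected outcome is a 1.7-fold higher number from compound 1 to compound 4 (0.24 log units; within the scatter). For compound 4 the estimated value is 400 nM, with an expected range from 80 nM to 3000 nM.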

Compound 4, half-maximal inhibitory concentration: 18 nM
Compound 4: the middle estimate sits 22-fold (1.35 log units) above what was measured, and the stated range ends above it.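

In this assay, methoxy in place of hydrogen gave a 13-fold lower number from compound 1 to compound 4 (1.11 log units; beyond the scatter), so this aromatic carbon, ortho to a large group, responds strongly to substitution. The earlier compounds shown here changed only the methoxy-bearing phenyl and said nothing about the benzoyl side of the molecule, where a single added group now proves enough to give a large step. The data shown give no cause for this step. From the compounds shown here alone, it remains open whether methoxy itself is needed at this place or whether a hydroxyl, a methyl or an ethoxy would serve as well.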